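The compounds below may be only part of what the source reports. "The series", "measured", "known", "first", "only" and "open" are said of these compounds alone.

Measured compounds:
compound 1, `CC(=O)c1ccc(OCc2ccccc2F)cc1`, gives 56.9 nM
compound 2, `CC(=O)c1ccc(OCc2cccc(F)c2)cc1`, gives 83.1 nM
compound 3, `CC(=O)c1ccc(OCc2ccccc2C(F)(F)F)cc1`, gives 183 nM

All three compounds were tested in an assay on isolated protein for inhibition of Amine oxidase [flavin-containing] B (Homo sapiens), read by Amplex Red, with a stated time of 15 min; a lower number here means a stronger inhibitor, a higher number a weaker inhibitor. Compound 1 and compound 2 are built from the same atoms joined differently; the difference between the two cores is not broken down here, and their two values lie within the usual scatter of each other, so nothing separates them. Compound 3 arises from compound 1 by one change, (trifluoromethyl in place of fluoro on an aromatic carbon), and that change gave a 3.2-fold higher number from compound 1 to compound 3 (0.51 log units; beyond the scatter).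

Compound 4, `CC(=O)c1ccc(OCc2cccc(C(F)(F)F)c2)cc1`, has not yet been tested. It arises from compound 2 by trifluoromethyl in place of fluoro on an aromatic carbon. The group that leaves and the group that enters are the same as in the move from compound 1 to compound 3, but the place is not identical: in compound 3 the trifluoromethyl sits ortho to a large group, in compound 4 it sits meta to a large group. It is therefore the same kind of change rather than the same change, and a single measured example is a thin basis for expecting the same size of step.

Among the compounds with values here, with that caution, compound 4 is expected to show a step of about a 2.8-fold higher number from compound 2 to compound 4 (0.44 log units; beyond the scatter), a little smaller than the earlier one because the one measured example gave a 3.2-fold higher number from compound 1 to compound 3 (0.51 log units; beyond the scatter) at a different place. The estimate for compound 4 in this assay is 230 nM, with a likely range from 100 nM to 550 nM.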

Compound 4, half-maximal inhibitory concentration: 58.2 nM
Estimate against measurement, compound 4: 4.0-fold (0.60 log units) above, and the stated range ends above it.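

In this assay, within the data shown here, replacing fluoro with trifluoromethyl, meta to a large group, gave a 1.4-fold lower number from compound 2 to compound 4 (0.15 log units; within the scatter), so on this core the swap produced no step that can be told apart from ordinary repeat variation. Set beside the earlier example, the same kind of swap did not carry over with the same size from one core to the other: the same change on two cores in this assay, a 3.2-fold higher number (0.51 log units; beyond the scatter) from compound 1 to compound 3 and a 1.4-fold lower number (0.15 log units; within the scatter) from compound 2 to compound 4, 4.6-fold (0.66 log units) apart, beyond the scatter of two such steps. Among these compounds, this shows that a step measured on one core cannot simply be copied to the other, but with only two pairs it does not show why the steps differ, nor does it give a rule for any other place on the ring or any other swap.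

The compounds shown leave open how a plain hydrogen, a chloro, a methoxy or a nitrile group would compare with fluoro and trifluoromethyl at these places, and whether such groups would also give steps that differ from one core to the other. On these data alone, all four compounds also keep the same acetyl group, so it remains open how an amide or a carboxylic acid in its place would read in this assay.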